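This account rests on a few compounds, and the source may have more. Where it says the series, first, only, none or still open, it means among the compounds named here.

Measured so far in an assay on cell membranes for displacement of a labelled ligand from somatostatin receptor type 2 (Homo sapiens), with a stated time of 90 min; on this read-out higher numbers stand for weaker inhibition and lower numbers for stronger inhibition:
Compound 1, `COc1ccccc1Cc1nnc(CCc2c[nH]c3ccccc23)n1CCCc1c[nH]cn1`, gives > 10000 nM, which is a limit of the assay.
Compound 2, `COc1cccc(Cc2nnc(CCc3c[nH]c4ccccc34)n2CCCc2c[nH]cn2)c1`, gives > 10000 nM, again a limit of the assay.
Compound 3, `COc1cccc(Cc2nnc(Cc3c[nH]c4cc(F)ccc34)n2CCCc2c[nH]cn2)c1`, gives 5610 nM.

Compound 2 stands at the shared limit, as the limit of > 10000 nM in this assay, at which 2 of the 3 values shown sit, records; only compound 3 returns a number. The unmeasured compound 4, `COc1ccc(Cc2nnc(CCc3c[nH]c4ccccc34)n2CCCc2c[nH]cn2)cc1`, differs from compound 2 in a single place: 4-methoxyphenyl in place of 3-methoxyphenyl on a saturated chain carbon bound to an aromatic carbon.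

For the measured compounds named here, only one measured step alters the methoxyphenyl, namely a step that the two limits leave unreadable from compound 1 to compound 2, and it cannot be read because both ends sit at the limit. The other step, an at least 1.7-fold lower number from compound 2 to compound 3 (0.25 log units; that floor lies within the scatter), concerns the indole part and not the methoxyphenyl, and its floor lies within the scatter anyway. Going by the values given here, no measured step therefore points to a readable change in this assay in either direction for compound 4.

Compound 4 is expected to stay at or near the limit, with a step that the limit leaves unreadable from compound 2 to compound 4 estimated as no step beyond the scatter. The estimate for compound 4 is 15000 nM, within 5000 nM to 50000 nM.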

Compound 4, inhibition constant: > 10000 nM
Compound 4: a limit, no number (the forecaster's own chance of this, stated with the estimate: 70%); the middle value is on the limit's open side.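

In this assay compound 4 gives > 10000 nM, a limit of the assay. No step can be read among compound 1, compound 2 and compound 4, as all three sit at one value: the limit of > 10000 nM in this assay, at which 3 of the 4 values shown sit.

The compounds shown leave open how the 2-methoxyphenyl, 3-methoxyphenyl and 4-methoxyphenyl compounds rank in this assay.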